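A few compounds are considered here, and "the series" means these few. Any claim that something is new, unique, unknown or untested is made for them only; others in the source may bear on it.

Within the data shown here, in a toxicity assay on GES1 cells (Homo sapiens) for inhibition, read by MTT assay, with a stated time of 72 h (on this read-out lower numbers stand for stronger inhibition and higher numbers for weaker inhibition), compound 1 `Cc1cc(N2CC[C@@H](C)[C@@H](N(C)c3ncnc4[nH]ccc34)C2)n2nc(SCc3ccc(C(F)(F)F)cc3)nc2n1` gives 17300 nM, the only number among the three values so far. Compound 2 `C[C@@H]1CCN(c2cc(-c3ccccc3)nc3ncnn23)C[C@@H]1N(C)c1ncnc2[nH]ccc12` gives > 100000 nM in this assay, which is a limit rather than a number. Compound 3 `CCc1cc(N2CC[C@@H](C)[C@@H](N(C)c3ncnc4[nH]ccc34)C2)n2ncnc2n1` gives > 100000 nM in this assay, also a limit. The step that the two limits leave unreadable from compound 2 to compound 3 is unreadable, since both ends sit at the limit of > 100000 nM in this assay, at which 2 of the 3 values shown sit. Compound 4 `Cc1cc(N2CC[C@@H](C)[C@@H](N(C)c3ncnc4[nH]ccc34)C2)n2nc(SCc3ccc(Cl)cc3)nc2n1` differs from compound 1 by chloro in place of trifluoromethyl on an aromatic carbon. No measured step involves this change, so nothing shown speaks for a shift in either direction, and the expected step of a 1.2-fold higher number from compound 1 to compound 4 (0.06 log units; within the scatter) in this assay is one that stays within the usual scatter. Compound 4 is therefore estimated at 20000 nM, with a range from 6000 nM to 70000 nM.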

Compound 4, half-maximal inhibitory concentration: > 100000 nM
Compound 4 was reported as a limit; the forecaster's own chance of this, stated with the estimate: 20%; at least 5.0-fold (0.69 log units) between middle value and limit.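

At this place on the benzyl group, chloro in place of trifluoromethyl gives an at least 5.7-fold higher number from compound 1 to compound 4 (0.76 log units; beyond the scatter) in this assay and so is not a neutral swap. Among these compounds, this one group is enough to separate compound 1, the only compound here with a number, from a compound at the limit. The full size of the step cannot be read, as compound 4 gives a limit and not a number: the limit of > 100000 nM in this assay, at which 3 of the 4 values shown sit.

The compounds shown leave open whether a methoxy group, a nitrile or plain hydrogen at this place would give a number or a limit. They also leave open whether other groups on the ring behave like trifluoromethyl or like chloro.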